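Sulfur-linked acetamide replaces the cyanophenoxy arm

The source may report more compounds than this note shows. Statements on the series, on what has been measured and on what is new or still open speak of the compounds shown alone.

For the measured compounds named here, compound 3 `COc1ccc(C2Nc3ccccc3C(=O)N2Cc2ccccc2)cc1COc1ccc(C#N)cc1` gives 11.7% in a functional assay on HEK-EM293 cells for agonist activity at Thyrotropin receptor (Homo sapiens), read by ELISA and cAMP accumulation, with a stated time of 1 h (a higher number here means a larger maximal response, a lower number a smaller maximal response), the lowest of the three numbers known. Going by the values given here, compound 2 `COc1ccc(C2Nc3ccccc3C(=O)N2Cc2ccccc2)cc1COc1ccccc1` gives 25.6%, and the one single-site step known is a number 13.9 percentage points lower from compound 2 to compound 3 (beyond the scatter). Among the compounds with values here, compound 1 `COc1ccc(C2Nc3ccccc3C(=O)N2c2ccccc2)cc1COc1ccc(NC(C)=O)cc1` gives 75.1%, but it differs from compound 3 in more than one place, so its number shows only that the compound carrying an acetamide reaches the largest response of the set. Compound 4 `COc1ccc(C2Nc3ccccc3C(=O)N2Cc2ccccc2)cc1CSc1ccc(NC(C)=O)cc1` differs from compound 3 thus: (4-acetamidophenyl)sulfanyl in place of 4-cyanophenoxy on a saturated chain carbon bound to an aromatic carbon. Since the cyano is lost and an acetamide enters, a rise beyond the scatter is expected because of a number 13.9 percentage points lower from compound 2 to compound 3 (beyond the scatter), tempered by the unmeasured sulfur link. Compound 4 is therefore estimated at 35%, between 15% and 65%, an expected step of a number 23.3 percentage points higher from compound 3 to compound 4 (beyond the scatter).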

Compound 4, largest response reached (Emax), in percent of the reference or control that the assay uses: 95.7%
Compound 4: middle estimate off by 60.7 percentage points, on the low side; measured number outside the range, above it.
By their numbers in this assay, from the lowest: compound 3; then compound 2; then compound 1; then compound 4.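

At this position, on a saturated chain carbon bound to an aromatic carbon, the arm can decide the response in this assay: the change to (4-acetamidophenyl)sulfanyl gives a number 70.1 percentage points higher from compound 2 to compound 4 (beyond the scatter) and a number 84 percentage points higher from compound 3 to compound 4 (beyond the scatter) in the two single-site comparisons. Both steps are large, whether phenoxy or 4-cyanophenoxy leaves, and far exceed the modest effect of adding the cyano group. No evidence available here explains the rise.

Going by these compounds, the sulfur link and the acetamide enter together, so their separate shares remain open. On these data alone, whether an aminophenyl, a sulfone link or a longer acyl chain would keep this response also remains open.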